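The compounds below may be only part of what the source reports. "The series", "measured", "known", "first", "only" and "open" are said of these compounds alone.

Working notes on a series of diacylhydrazides carrying a tert-butyl group on the hydrazide nitrogen and one benzoyl arm, with variation confined to the second acyl group. Compound 1 `CC(C)(C)N(NC(=O)c1ccccc1)C(=O)c1ccccc1F` gives 309 nM in an assay on cells for agonist activity at ecdysone receptor (Bombyx mori), read by a luciferase reporter, with a stated time of 24 h; on this read-out higher numbers stand for an effect only at larger amounts of compound and lower numbers for an effect already at smaller amounts. Compound 2 `CCc1ccccc1C(=O)N(NC(=O)c1ccccc1)C(C)(C)C` gives 589 nM in this assay, and the step of a 1.9-fold higher number from compound 1 to compound 2 (0.28 log units; within the scatter). Compound 3 `CC(C)(C)N(NC(=O)c1ccccc1)C(=O)c1ccc(Cl)cc1Cl` gives 117 nM in this assay and stands lowest of the three measured numbers: its nearest neighbour is compound 1, with a 2.6-fold lower number from compound 1 to compound 3 (0.42 log units; beyond the scatter), and its furthest is compound 2, with a 5.0-fold lower number from compound 2 to compound 3 (0.70 log units; beyond the scatter).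

Compound 4 `CCCCCCC(=O)N(NC(=O)c1ccccc1)C(C)(C)C` is not yet measured. The change from compound 3 is hexyl in place of 2,4-dichlorophenyl on a carbonyl carbon. Within the data shown here, no measured step bears directly on this change: all three measured compounds keep an aromatic ring on this carbonyl carbon, and the two steps that touch this position, from compound 1 and from compound 2 to compound 3, only exchange substituents on that ring and move the number over a modest span. Among the measured compounds shown here, removing the ring altogether has no precedent here, so the uncertainty is wide. The step into compound 4 is expected to run upward in this assay, as a 13-fold higher number from compound 3 to compound 4 (1.11 log units; beyond the scatter), beyond what the substituent exchanges produced. Compound 4 is thus estimated at 1500 nM in this assay, within a range from 300 nM to 8000 nM.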

Compound 4, half-maximal effective concentration: 7240 nM
The estimate for compound 4 lay 4.8-fold (0.68 log units) below the measured number; low and high end bracket the measured number.
By their numbers in this assay, from the lowest: compound 3; then compounds 1 and 2 (each within the scatter of the next); then compound 4.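

In this assay, exchanging the aromatic ring on this carbonyl carbon for hexyl gives a 62-fold higher number from compound 3 to compound 4 (1.79 log units; beyond the scatter), and the same kind of exchange gives a 12-fold higher number from compound 2 to compound 4 (1.09 log units; beyond the scatter) and a 23-fold higher number from compound 1 to compound 4 (1.37 log units; beyond the scatter). All three steps are large, and each exceeds the largest change produced by exchanging substituents on the ring, a 5.0-fold lower number from compound 2 to compound 3 (0.70 log units; beyond the scatter), so this position shows a much wider response to replacing the ring than to altering it, and compound 4 is the least potent of the four in this assay. Nothing available explains the size of these steps.

Among these compounds, whether the rise belongs to the loss of the aromatic ring or to the hexyl chain itself stays open: compound 4 is the only member of the series without a ring on this carbonyl carbon, and a single chain cannot separate the two readings. Going by these compounds, a cyclohexyl group, a benzyl group, or a butyl chain at this position would help to separate them, and whether the step keeps its size with another group in place of the benzoyl arm or the tert-butyl group also remains unknown.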